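The source may report more compounds than this note shows. Statements on the series, on what has been measured and on what is new or still open speak of the compounds shown alone.

Measured values:
Compound 1 `COc1ccc(Cc2nnc(NC(=O)/C(C#N)=C/c3ccccc3OS(=O)(=O)c3ccccc3[N+](=O)[O-])s2)cc1`: 18%
Compound 2 `COc1ccc(S(=O)(=O)Oc2ccccc2/C=C(\C#N)C(=O)Nc2nnc(Cc3ccc(Cl)cc3)s2)cc1`: 26%
Compound 3 `N#C/C(=C\c1ccccc1OS(=O)(=O)c1ccc([N+](=O)[O-])cc1)C(=O)Nc1nnc(Cc2ccc(Cl)cc2)s1`: 19%

In an ADME assay on HEK-293T cells (Homo sapiens) for inhibition, read by CCK-8 assay, with a stated time of 48 h, tested at 20 uM (on this read-out lower numbers stand for less inhibition of growth and higher numbers for more inhibition of growth at the one concentration tested), compound 3 gives 19%, which lies within the usual scatter of the values of both compound 1 and compound 2. Compound 4 `N#C/C(=C\c1ccccc1OS(=O)(=O)c1ccccc1[N+](=O)[O-])C(=O)Nc1nnc(Cc2ccc(Cl)cc2)s1` has the same atoms as compound 3, joined differently: 2-nitrophenyl in place of 4-nitrophenyl on a sulfonyl sulfur. In short, 2-nitrophenyl stands in place of 4-nitrophenyl on a sulfonyl sulfur. Within the data shown here, no measured step covers this exact swap. The nearest is a number 7 percentage points lower from compound 2 to compound 3 (within the scatter), a change on the same group that stayed within the scatter. Compound 1, which also carries 2-nitrophenyl on its sulfonyl sulfur but differs elsewhere, gives 18%. The expected change in this assay therefore stays within the scatter, with no clear direction: the estimate is a number 1 percentage points higher from compound 3 to compound 4 (within the scatter). Compound 4 is expected at 20%, with an estimated range from 10% to 31%.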

Compound 4, percent growth inhibition at one concentration: 20%
For compound 4 middle estimate and measured number coincide at the digits printed, and the stated range covers the measured number.
By their numbers in this assay, from the lowest: compounds 1, 3, 4 and 2 (each within the scatter of the next).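

In this assay, moving the nitro group from 4-nitrophenyl to 2-nitrophenyl on the sulfonyl sulfur gives a number 1 percentage points higher from compound 3 to compound 4 (within the scatter) and so leaves growth inhibition essentially unchanged. Two further steps also stay within the scatter: 2-nitrophenyl in place of 4-methoxyphenyl on that sulfur gives a number 6 percentage points lower from compound 2 to compound 4 (within the scatter) and swapping methoxy for chloro on an aromatic carbon, with 2-nitrophenyl held constant, gives a number 2 percentage points higher from compound 1 to compound 4 (within the scatter) in this comparison. No evidence on the cause of these results is available. As far as these compounds go, whether an amine or a carboxylic acid on that phenyl ring, or a longer chain on the sulfonyl sulfur in place of the ring, would shift the number beyond the scatter remains open.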